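The source may report more compounds than this note shows. Statements on the series, on what has been measured and on what is new or still open speak of the compounds shown alone.

Measured in a functional assay on HT-1080 cells (Homo sapiens) for cytotoxicity, read by MTT assay, with a stated time of 72 h; on this read-out lower numbers stand for stronger inhibition and higher numbers for weaker inhibition:
- compound 1 `COc1cc(O)c(C)c2c1CC[C@H](c1ccc(O)cc1)O2`: 37000 nM
- compound 2 `COc1cc2c(cc1O)C[C@@H](Cc1ccc(O)cc1)CO2`: 17500 nM
- compound 3 `COc1ccc(C(=O)CCc2c(OC)cc(O)cc2OC)cc1`: > 100000 nM

Compound 3 has no exact number, and its entry of > 100000 nM is a limit of the assay. It therefore marks the weak end of this small set only loosely.

Compound 4 `COc1cc(O)cc(OC)c1CCC(=O)c1ccc(O)cc1` differs from compound 3 in one place: hydrogen in place of methyl on an oxygen on an aromatic ring. This puts hydrogen in place of methyl on an oxygen on an aromatic ring, turning a methoxy into a hydroxy.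

For the measured compounds named here, no measured pair of compounds shows this change, so any expectation is rough. Going by the values given here, the only exact numbers come from compound 1 at 37000 nM and compound 2 at 17500 nM, and both differ from compound 3 in more than this one place. Among the compounds with values here, they suggest only that a measurable value is plausible.

The expected change is modest and toward stronger inhibition, shown as an at least 1.8-fold lower number from compound 3 to compound 4 (0.25 log units; that floor lies within the scatter). A reading that stays at the limit would not be surprising. The estimated value for compound 4 is 55000 nM, with an expected range of 22000 nM to 100000 nM.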

Compound 4, half-maximal inhibitory concentration: 67200 nM
Estimate against measurement, compound 4: 1.2-fold (0.09 log units) below, within the range that was stated.
By their numbers in this assay, from the lowest: compound 2; then compounds 1 and 4 (each within the scatter of the next). At a limit, above all of these: compound 3.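

Putting hydrogen in place of methyl on an oxygen on an aromatic ring, turning a methoxy into a hydroxy, gives a value that can be read as an exact number: in this assay, compound 4 gives 67200 nM. The entry for compound 3, > 100000 nM, is a limit of the assay and not a number. The change therefore reads as an at least 1.4-fold lower number from compound 3 to compound 4 (0.17 log units; that floor lies within the scatter), and its true size stays unknown because one end of the step rests on a limit: the limit of > 100000 nM in this assay, at which 1 of the 4 values shown sits.

The compounds shown leave open how a longer chain on that same oxygen, such as an ethyl group, would read, or an amine in place of the hydroxy. They also leave open whether the same change at the remaining methoxy groups of compound 4 would give a similar step.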